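The source may hold more compounds than are shown below. What is called first, only, known or untested is meant among the compounds shown, and "the series" means these compounds.

Measured compounds:

Compound 1, `COc1cc(C(C)O)ccc1OCCCN1CCC(C(c2ccc(F)cc2)c2ccc(F)cc2)CC1`: 10 nM
Compound 2, `COC(=O)c1ccc(OCCCN2CCC(C(c3ccc(F)cc3)c3ccc(F)cc3)CC2)c(OC)c1`: 1.26 nM
Compound 3, `Fc1ccc(OCCCN2CCC(C(c3ccc(F)cc3)c3ccc(F)cc3)CC2)cc1`: 1.26 nM

All three were tested in a functional assay (aorta) with Oryctolagus cuniculus as the target; on this read-out higher numbers stand for weaker binding and lower numbers for tighter binding. Compound 3 sits level with compound 2, the two together giving the lowest numbers of the set; the step of no change at the digits printed from compound 2 to compound 3 (within the scatter) is within the scatter, so no order between them can be claimed. Compound 1 stands furthest away: the step of a 7.9-fold lower number from compound 1 to compound 3 (0.90 log units; beyond the scatter) is beyond the scatter, though only modest.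

Compound 4, `CN(CCCN1CCC(C(c2ccc(F)cc2)c2ccc(F)cc2)CC1)c1ccccc1`, has not yet been measured. It differs from compound 3 in one place: methyl(phenyl)amino in place of 4-fluorophenoxy on a saturated chain carbon, three bonds along the chain from an amine nitrogen in a ring. Going by the values given here, none of the measured steps touches this spot in the same way. The steps of a 7.9-fold lower number from compound 1 to compound 3 (0.90 log units; beyond the scatter) and no change at the digits printed from compound 2 to compound 3 (within the scatter) change what sits on the oxygen on a saturated carbon and leave the oxygen itself in place, yet they show that swapping the group there moves this assay either modestly or not at all. On that limited basis a small step is expected, with the number for compound 4 drifting slightly higher, and the expected step of a 2.0-fold higher number from compound 3 to compound 4 (0.30 log units; within the scatter) should stay within or near the scatter. Compound 4 is therefore estimated at 2.5 nM in this assay, within a range of 0.6 nM to 10 nM.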

Compound 4, dissociation constant: 2 nM
Compound 4: middle estimate off by 1.3-fold (0.10 log units), on the high side; the range from low to high includes it.
By their numbers in this assay, from the lowest: compounds 2, 3 and 4 (each within the scatter of the next); then compound 1.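

This is the first change shown in which the oxygen itself gives way, with a nitrogen carrying a methyl group linking the phenyl ring to the saturated chain, and in this assay the step (a 1.6-fold higher number from compound 3 to compound 4 (0.20 log units; within the scatter)) lies within the scatter. The two groups match in what can be counted, with 8 heavy atoms, one six-membered aromatic ring and 1 hydrogen-bond acceptor each, so at this place neither the oxygen link nor the fluorine proves necessary for a low number, while the step (a 5.0-fold lower number from compound 1 to compound 4 (0.70 log units; beyond the scatter)) shows that methyl(phenyl)amino also keeps the modest gap beyond the scatter from compound 1. Nothing available explains why the exchange leaves the read-out within the scatter.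

The exchange replaces the oxygen and removes the fluorine at once, so the compounds shown cannot separate the two changes; methyl(4-fluorophenyl)amino or plain phenoxy on the same chain would do that. Also open, from the compounds shown here alone, is whether the methyl on the nitrogen matters, a question that phenylamino at this place would address.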